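The compounds below may be only part of what the source reports. "The series", "measured", "known", "first", "only" and "open" are said of these compounds alone.

In a functional assay on MKN-45 cells (Homo sapiens) for cytotoxicity, read by MTT assay, with a stated time of 48 h (a higher number here means a weaker inhibitor, a lower number a stronger inhibitor), compound 1 `CCc1nnc(SCC(=O)c2ccc(Cl)cc2)n1N1C(=O)c2ccccc2C1=O` gives only a limit, > 200000 nM. Compound 2 `CCCc1nnc(SCC(=O)c2ccc(C)cc2)n1N1C(=O)c2ccccc2C1=O` likewise gives only a limit, > 200000 nM. Compound 3 `C=CCSc1nnc(-c2cc(OC)c(OC)c(OC)c2)n1N1C(=O)c2ccccc2C1=O` also reaches only a limit in this assay, > 200000 nM. Where compound 3 stands is thus known only as a boundary: every measured value sits at the same place, (the limit of > 200000 nM in this assay, at which 3 of the 3 values shown sit), so no order among compound 1, compound 2 and compound 3 can be drawn, and no measured step exists between any pair differing in one place. Compound 4 `COc1cc(-c2nnc(SCC(=O)c3ccc(Cl)cc3)n2N2C(=O)c3ccccc3C2=O)cc(OC)c1OC` carries (4-chlorophenyl)carbonyl in place of vinyl on a saturated chain carbon bound to a sulfur, which, cut one bond further out, reads allyl to ((4-chlorophenyl)carbonyl)methyl. The measured compounds set no size or direction for this change in this assay; nothing beyond the scatter is indicated. Compound 4 is therefore expected to give 250000 nM, within 100000 nM to 600000 nM. The estimated step is a step that the limit leaves unreadable from compound 3 to compound 4, and the result is expected most probably to end again at the limit.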

Compound 4, half-maximal inhibitory concentration: 26600 nM
Estimate against measurement, compound 4: 9.4-fold (0.97 log units) above; measured number outside the range, below it.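

In this assay, within the data shown here, (4-chlorophenyl)carbonyl in place of vinyl on a saturated chain carbon bound to a sulfur gives an at least 7.5-fold lower number from compound 3 to compound 4 (0.87 log units; beyond the scatter), the first readable change at this position. On an aromatic carbon, 3,4,5-trimethoxyphenyl in place of ethyl gives an at least 7.5-fold lower number from compound 1 to compound 4 (0.87 log units; beyond the scatter), so this second position also registers a change. Compound 3 carries the 3,4,5-trimethoxyphenyl group and compound 1 the (4-chlorophenyl)carbonyl group, yet each stays at the limit and only compound 4, which holds both, leaves it: the limit of > 200000 nM in this assay, at which 3 of the 4 values shown sit.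

From the compounds shown here alone, the true size of either step remains unknown, as compound 1 and compound 3 give only limits. Also open, going by these compounds, is whether an amine or a carboxylic acid could replace (4-chlorophenyl)carbonyl on that chain carbon and still leave the limit behind.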